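Chloro to amino on the fused ring of the shared core

The compounds below may be only part of what the source reports. "The series", "measured", "known", "first", "only" and "open" are said of these compounds alone.

The series rests on the core of compound 1 `Nc1nn(C(=O)Nc2ccc(Cc3ccccc3)cc2)c2ccccc12`; compound 2 `Nc1nn(C(=O)Nc2ccc(Cc3ccccc3)cc2)c2ccc(Cl)cc12` carries a chloro on that core. In a functional assay on RPMI8266 cells (Homo sapiens) for antiproliferative activity, read by sulforhodamine B assay, with a stated time of 48 h (a lower number here means a stronger inhibitor of growth, a higher number a weaker inhibitor of growth), compound 1 gives 25800 nM, and compound 2 gives 46500 nM. Within the data shown here, the single measured step, a 1.8-fold higher number from compound 1 to compound 2 (0.26 log units; within the scatter), is the only change at this part of the structure so far. Compound 2 stands beside compound 1 on the numbers shown; the gap between them is within the scatter, so the two are not separated.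

Compound 3 `Nc1ccc2c(c1)c(N)nn2C(=O)Nc1ccc(Cc2ccccc2)cc1` differs from compound 2 by amino in place of chloro on an aromatic carbon. Among the measured compounds shown here, no measured step covers an amino at this place; the only related step, chloro for hydrogen, stayed within the scatter. The step expected is therefore small, a 1.6-fold lower number from compound 2 to compound 3 (0.19 log units; within the scatter), with no direction beyond the scatter. For compound 3 the estimate in this assay is 30000 nM, ranging from 12000 nM to 90000 nM.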

Compound 3, concentration for total growth inhibition: 35000 nM
Compound 3: middle estimate off by 1.2-fold (0.07 log units), on the low side; the measured number falls inside the stated range.
By their numbers in this assay, from the lowest: compounds 1, 3 and 2 (each within the scatter of the next).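

In this assay amino in place of chloro gives a 1.3-fold lower number from compound 2 to compound 3 (0.12 log units; within the scatter) and amino in place of hydrogen gives a 1.4-fold higher number from compound 1 to compound 3 (0.13 log units; within the scatter) so hydrogen, chloro and amino at this place are not separated. The earlier step covered only chloro, whereas this change also brings in a hydrogen-bond donor and a hydrogen-bond acceptor, and the number still stays within the scatter. No measurement at hand gives a reason for this result.

As far as these compounds go, whether a larger group at this place, such as acetamide or a carboxylic acid, would move the number beyond the scatter remains open. Also open, from the compounds shown here alone, is whether amino or chloro on another aromatic carbon of the same six-membered ring would behave as they do here.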